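This account rests on a few compounds, and the source may have more. Where it says the series, first, only, none or still open, it means among the compounds named here.

Measured in a functional assay on HGC cells (Homo sapiens) for cytotoxicity, read by MTT assay, with a stated time of 48 h; on this read-out lower numbers stand for stronger inhibition and higher numbers for weaker inhibition:
Compound 1 `CCn1c(/C=C2/C(=O)Nc3ccc(F)cc32)nc2ccccc21`: > 50000 nM, a limit.
Compound 2 `CCn1c(/C=C2/C(=O)Nc3ccccc32)nc2ccccc21`: > 50000 nM, a limit.
Compound 3 `CC(C)n1c(/C=C2/C(=O)Nc3ccccc32)nc2ccccc21`: 33500 nM.

Compound 2 has no number of its own, only the limit > 50000 nM. This is the limit of > 50000 nM in this assay, at which 2 of the 3 values shown sit. Compound 4 `CCn1c(/C=C2/C(=O)Nc3ccc(C)cc32)nc2ccccc21` carries methyl in place of hydrogen on an aromatic carbon of compound 2: methyl in place of hydrogen on an aromatic carbon.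

Within the data shown here, two measured steps bear on this change. The closer in kind also concerns an aromatic carbon, but it is a step that the two limits leave unreadable from compound 1 to compound 2. The other also brings in a methyl, though on a saturated chain carbon, and it is an at least 1.4-fold lower number from compound 2 to compound 3 (0.17 log units; that floor lies within the scatter). Neither gives a size that can be carried over, so no step beyond the scatter is expected in this assay, and a report of only a limit for compound 4 is the likeliest outcome. The expected change is a number no higher from compound 2 to compound 4 (the limit leaves the size open). For compound 4 the estimated value is 50000 nM, with an expected range from 20000 nM to 100000 nM.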

Compound 4, half-maximal inhibitory concentration: > 50000 nM
Compound 4 ended at the assay's limit (the forecaster's own chance of this, stated with the estimate: 70%); the middle value lies on the limit itself.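

The steps from compound 2 to compound 4 and from compound 1 to compound 4 cannot be read, since all three compounds give only a limit: the limit of > 50000 nM in this assay, at which 3 of the 4 values shown sit.

The compounds shown leave open whether methyl in place of hydrogen on an aromatic carbon changes the number at all, and by how much.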